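The compounds below may be only part of what the source reports. "The series", "measured", "known", "first", "only" and "open" are said of these compounds alone.

Measured so far in a functional assay on A549 cells (Homo sapiens) for inhibition, read by MTT assay, with a stated time of 24 h; a lower number here means a stronger inhibitor, a higher number a weaker inhibitor:
compound 1 `CC1(C)[C@H]2CC[C@]1(C)N(Cc1cn(-c3ccccc3Br)nn1)C(=O)C2` gives 130 nM;
compound 2 `CC1(C)[C@H]2CC[C@]1(C)N(Cc1cn(-c3cccc(Cl)c3)nn1)C(=O)C2` gives 60 nM;
compound 3 `Cc1ccc(-n2cc(CN3C(=O)C[C@@H]4CC[C@@]3(C)C4(C)C)nn2)cc1` gives 400 nM.

Compound 1 holds the second highest of the three numbers: compound 2 lies a 2.2-fold lower number from compound 1 to compound 2 (0.34 log units; beyond the scatter) away, while compound 3 stands a 3.1-fold higher number from compound 1 to compound 3 (0.49 log units; beyond the scatter) off. The step to compound 4 `Cc1cccc(-n2cc(CN3C(=O)C[C@@H]4CC[C@@]3(C)C4(C)C)nn2)c1` is 3-methylphenyl in place of 2-bromophenyl on an aromatic nitrogen. Among the compounds with values here, two measured steps bear on it. Moving the halogen to the 3-position gave a 2.2-fold lower number from compound 1 to compound 2 (0.34 log units; beyond the scatter), whereas a methyl at the 4-position gave a 3.1-fold higher number from compound 1 to compound 3 (0.49 log units; beyond the scatter), and between those two a 6.7-fold higher number from compound 2 to compound 3 (0.82 log units; beyond the scatter). The two trends pull against each other, so compound 4 is expected to land near compound 1, a step of about a 1.2-fold higher number from compound 1 to compound 4 (0.06 log units; within the scatter) in this assay. The estimate for compound 4 is 150 nM, with a range from 60 nM to 400 nM.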

Compound 4, half-maximal inhibitory concentration: 50 nM
Estimate against measurement, compound 4: 3.0-fold (0.48 log units) above; the whole stated range lies above it.
By their numbers in this assay, from the lowest: compounds 4 and 2 (each within the scatter of the next); then compound 1; then compound 3.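

In this assay, 3-methylphenyl in place of 2-bromophenyl gives a 2.6-fold lower number from compound 1 to compound 4 (0.41 log units; beyond the scatter), and moving the methyl alone, from 4-methylphenyl to 3-methylphenyl, gives an 8.0-fold lower number from compound 3 to compound 4 (0.90 log units; beyond the scatter). Methyl and chloro do not separate on this ring, with a 1.2-fold lower number from compound 2 to compound 4 (0.08 log units; within the scatter) lying within the scatter. Among these four compounds, then, where the group sits on the phenyl counts for more than which group it is: compounds 2 and 4 stand apart from compounds 1 and 3.

No measured evidence gives a cause for this. On these data alone, whether a methoxy, an amine or a carboxylic acid in the same place would match methyl and chloro remains open.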